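Ether-side replacement: from compound 2 to compound 4

A few compounds are considered here, and "the series" means these few. Any claim that something is new, unique, unknown or untested is made for them only; others in the source may bear on it.

Measured compounds:
- compound 1 `CNC(=O)c1cc(Oc2ccc(NC(=O)c3nn(-c4ccccc4C(F)(F)F)c(=O)cc3C)cc2F)ccn1`: in a functional assay on A549 cells (Homo sapiens) for cytotoxicity, read by MTT assay, with a stated time of 72 h (a lower number here means a stronger inhibitor, a higher number a weaker inhibitor), compound 1 gives > 40000 nM, a limit of the assay.
- compound 2 `CNC(=O)c1cc(Oc2ccc(NC(=O)c3nn(-c4ccc(C)cc4)c(=O)cc3C)cc2F)ccn1`: in this assay compound 2 gives 11500 nM.
- compound 3 `CNC(=O)c1cc(Oc2ccc(NC(=O)c3nn(-c4ccccc4F)c(=O)cc3C)cc2F)ccn1`: in this assay compound 3 gives > 40000 nM, a limit of the assay.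

For the measured compounds named here, compound 2 holds the only number in the set; the other two values sit at the limit (the limit of > 40000 nM in this assay, at which 2 of the 3 values shown sit). Both readable steps, an at least 3.4-fold lower number from compound 1 to compound 2 (0.54 log units; beyond the scatter) and an at least 3.4-fold higher number from compound 2 to compound 3 (0.54 log units; beyond the scatter), concern the group on the aromatic nitrogen. Compound 4 `Cc1ccc(-n2nc(C(=O)Nc3ccc(Oc4ncnc5sccc45)c(F)c3)c(C)cc2=O)cc1` changes a different part of compound 2: a group of 9 heavy atoms (6 carbon, 2 nitrogen, 1 sulfur; one five-membered aromatic ring with 1 hetero atom, one six-membered aromatic ring with 2 hetero atoms) in place of a group of 10 heavy atoms (7 carbon, 2 nitrogen, 1 oxygen; one six-membered aromatic ring with 1 hetero atom), on an oxygen on an aromatic ring. Going by the values given here, no measured step touches this position, so its effect in this assay cannot be read from the series, and a step of modest size in either direction is plausible. Compound 4 is expected at 9000 nM, within 2000 nM to 40000 nM. This estimate means an expected step of a 1.3-fold lower number from compound 2 to compound 4 (0.11 log units; within the scatter).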

Compound 4, half-maximal inhibitory concentration: > 40000 nM
Compound 4 was reported as a limit; the forecaster's own chance of this, stated with the estimate: 30%; middle value at least 4.4-fold (0.64 log units) from the limit.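

The ether side matters in this assay: with the 4-methylphenyl group kept, replacing 2-(methylcarbamoyl)pyridin-4-yl on the oxygen gives an at least 3.4-fold higher number from compound 2 to compound 4 (0.54 log units; beyond the scatter). For the compounds shown here, this is the first readable step away from the group on the aromatic nitrogen, so that group is not the only place where the series is sensitive. Compound 2 remains the only compound with a number, and the rest of the series sits at one limit: the limit of > 40000 nM in this assay, at which 3 of the 4 values shown sit.

Whether the ring or the methylcarbamoyl part accounts for the step stays open, as both change together. A carboxylic acid or an amine in place of methylcarbamoyl, on the same ring, would separate the two.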